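This account rests on a few compounds, and the source may have more. Where it says the series, first, only, none or still open, it means among the compounds named here.

Measured compounds:
- compound 1, `N=C(N)c1cccc(CN2CC[C@H](NS(=O)(=O)c3ccc4cnccc4c3)C2=O)c1`: > 2900 nM (a limit)
- compound 2, `N=C(N)c1cccc(CN2CC[C@H](NS(=O)(=O)c3ccc4ccncc4c3)C2=O)c1`: > 2900 nM (a limit)

Both measured compounds share one core and differ only in the attachment of the fused ring on the sulfonyl sulfur. In an assay on isolated protein for binding affinity to serine protease 1 (Homo sapiens) (on this read-out higher numbers stand for weaker inhibition and lower numbers for stronger inhibition), compound 1 gives > 2900 nM, which is a limit of the assay and not a number. In this assay compound 2 gives > 2900 nM, again a limit of the assay. The step that the two limits leave unreadable from compound 1 to compound 2 cannot be read, since the limit of > 2900 nM in this assay, at which 2 of the 2 values shown sit, hides any difference between the two.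

Compound 3 is `N=C(N)c1cccc(CN2CC[C@H](NS(=O)(=O)c3ccc4ccnc(N)c4c3)C2=O)c1`. It differs from compound 2 by amino in place of hydrogen on an aromatic carbon: the amino enters on an aromatic carbon of a six-membered aromatic ring with one nitrogen, next to the ring nitrogen, ortho to a fused ring and meta to a fused ring. For the measured compounds named here, no measured step bears on this change; the only step, from compound 1 to compound 2, concerns the attachment point, not a substituent, and is itself unreadable. With compound 2 standing only at a limit, an estimate for compound 3 has to be wide, and a further limit in this assay is a real possibility.

Compound 3 is estimated at 1500 nM, with a range from 150 nM to 6000 nM. The expected step of an at least 1.9-fold lower number from compound 2 to compound 3 (0.28 log units; that floor lies within the scatter) is thus towards stronger inhibition but uncertain in size.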

Compound 3, inhibition constant: > 2900 nM
Compound 3 gave a limit, no number; the forecaster's own chance of this, stated with the estimate: 45%; middle value at least 1.9-fold (0.28 log units) away from the limit.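

In this assay compound 3 gives > 2900 nM, a limit and not a number. The change from compound 2 to compound 3 therefore yields no readable step, because both compounds sit at the same limit: the limit of > 2900 nM in this assay, at which 3 of the 3 values shown sit. The compounds shown leave open whether amino in place of hydrogen changes inhibition at all, and how strongly any of them inhibits.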